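Adding a Third Methoxy Group: An Expected Limit

The compounds below may be only part of what the source reports. "The series", "measured", "known", "first", "only" and "open" are said of these compounds alone.

Compound 1 `COc1ccc(CS(=O)(=O)/C=C/c2ccc(F)cc2)cc1` is examined in a functional assay on DU-145 cells (Homo sapiens) for antiproliferative activity, read by trypan blue exclusion (on this read-out higher numbers stand for weaker inhibition and lower numbers for stronger inhibition), where compound 1 gives 1250 nM. Compound 2 `COc1ccc(CS(=O)(=O)/C=C/c2ccc(F)cc2OC)cc1` differs from it by methoxy in place of hydrogen on an aromatic carbon. In this assay compound 2 gives 10000 nM, so that an 8.0-fold higher number from compound 1 to compound 2 (0.90 log units; beyond the scatter). Compound 3 `COc1ccc(CS(=O)(=O)/C=C/c2cc(OC)ccc2OC)cc1` shares a core with compound 1, but how the two cores differ is not broken down here. For compound 3 this assay reports only a limit, > 20000 nM, which is the limit of > 20000 nM in this assay, at which 1 of the 3 values shown sits. Compound 4 `COc1ccc(CS(=O)(=O)/C=C/c2cc(OC)c(OC)cc2OC)cc1` is not yet measured and differs from compound 3 by methoxy in place of hydrogen on an aromatic carbon. This is the same kind of change as that from compound 1 to compound 2, but the surroundings differ: in compound 4 the entering methoxy is ortho to a methoxy group, meta to a methoxy group and para to a large group, whereas in compound 2 it is ortho to a large group and meta to a fluoro group. Given an 8.0-fold higher number from compound 1 to compound 2 (0.90 log units; beyond the scatter), a further methoxy is expected to weaken inhibition again, so the step is estimated as a step that the limit leaves unreadable from compound 3 to compound 4. Compound 4 is therefore expected to give 50000 nM in this assay, most probably reported once more as a limit.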

Compound 4, half-maximal inhibitory concentration: > 20000 nM
Compound 4 was reported as a limit (the forecaster's own chance of this, stated with the estimate: 90%); the middle value lies beyond the limit too.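

No step can be read from compound 3 to compound 4, since this assay gives only a limit for each: the limit of > 20000 nM in this assay, at which 2 of the 4 values shown sit. On these data alone, whether the added methoxy changes inhibition at all, and by how much, stays open.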